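Swapping a cyclopentyl amide for a fluorinated chain

The source may report more compounds than this note shows. Statements on the series, on what has been measured and on what is new or still open speak of the compounds shown alone.

Three compounds have been run in an ADME assay on the whole organism (Mus musculus) for pharmacokinetics, using cassette dosing; on this read-out lower numbers stand for slow clearance and higher numbers for fast clearance. Compound 1 `Cc1ccc(C(=O)Nc2cn3ncnc3c(O[C@H]3CCN(C(=O)CC(C(F)(F)F)C(F)(F)F)[C@@H](C)C3)c2C)cn1`, which carries a 3,3,3-trifluoro-2-(trifluoromethyl)propyl group on its carbonyl carbon, shows the lowest value, with compound 1 giving 18.3 mL/min/kg. Compound 2 `Cc1ccc(C(=O)Nc2cn3ncnc3c(CN3CCN(C(=O)C4CCCC4)[C@@H](C)C3)c2C)cn1` shares the same core as compound 1 but bears a cyclopentyl group on the carbonyl carbon; in this assay compound 2 gives 88.3 mL/min/kg, the second highest of the three numbers, with steps to both neighbours that lie beyond the scatter. Compound 3 `Cc1ccc(C(=O)Nc2cc(F)cc(CN3CCN(C(=O)C4CCCC4)[C@@H](C)C3)c2C)cn1`, built on a different core, gives the highest value, with compound 3 at 767 mL/min/kg.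

Compound 4 `Cc1ccc(C(=O)Nc2cn3ncnc3c(CN3CCN(C(=O)CC(C(F)(F)F)C(F)(F)F)[C@@H](C)C3)c2C)cn1` has not yet been measured. It differs from compound 2 in one place: 3,3,3-trifluoro-2-(trifluoromethyl)propyl in place of cyclopentyl on a carbonyl carbon. This is the same group that sits on compound 1. Among the measured compounds shown here, no measured pair isolates this swap on the shared core, so the step is estimated rather than known. Because compound 1, carrying this very group, gives 18.3 mL/min/kg, compound 4 is expected to clear more slowly than compound 2, by a step of about a 2.2-fold lower number from compound 2 to compound 4 (0.34 log units; beyond the scatter). The estimate for compound 4 in this assay is 40 mL/min/kg, within a range from 15 mL/min/kg to 100 mL/min/kg.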

Compound 4, clearance: 75 mL/min/kg
Compound 4: middle estimate off by 1.9-fold (0.27 log units), on the low side, within the range that was stated.
By their numbers in this assay, from the lowest: compound 1; then compounds 4 and 2 (each within the scatter of the next); then compound 3.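

In this assay, among the compounds shown here, this is the first pair to isolate the swap on a carbonyl carbon, and it gives a 1.2-fold lower number from compound 2 to compound 4 (0.07 log units; within the scatter), so cyclopentyl and 3,3,3-trifluoro-2-(trifluoromethyl)propyl cannot be told apart here on the shared core. That changes how compound 1, which carries the same fluorinated chain, should be read: compound 1 gives 18.3 mL/min/kg but also differs from compound 4 elsewhere in the molecule, and on the core of compound 2 the chain on its own does not bring the number down beyond the scatter. Nothing available explains why the two groups give values this close.

From the compounds shown here alone, it remains open whether a carbonyl carbon carrying an amine, or a longer chain of carbon only, would move the clearance on this core. It is also unknown whether the same swap would leave the number unmoved on the different core of compound 3, which gives 767 mL/min/kg, or on the core of compound 1.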